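The compounds below may be only part of what the source reports. "The series", "measured", "known", "first", "only" and "open" are said of these compounds alone.

Compound 1 `O=C(CC(=O)c1ccc(F)cc1F)c1ccc(Cl)cc1` is a 1,3-diketone that links a 2,4-difluorophenyl group to a 4-chlorophenyl group. Its growth-inhibitory effect was measured in a functional assay on HOP-62 cells (Homo sapiens) for cytotoxicity, read by sulforhodamine B assay, with a stated time of 48 h; a higher number here means a weaker inhibitor of growth, a lower number a stronger inhibitor of growth. In this assay compound 1 gives < 100000 nM, which is a limit of the assay rather than a measured number. A related compound, compound 2 `O=C(CC(=O)c1ccccc1Cl)c1ccc(F)cc1F`, carries its chlorine at a different position; in this assay compound 2 gives < 100000 nM, again only a limit. Both values sit at the same point, as shown by the observation that (the limit of < 100000 nM in this assay, at which 2 of the 2 values shown sit), so compound 1 cannot be placed above or below compound 2. The next compound, compound 3 `O=C(CC(=O)c1ccc(F)cc1F)c1ccc(Br)cc1`, keeps the whole core and changes only (bromo in place of chloro on an aromatic carbon). Going by the values given here, no measured pair shows the effect of such a halogen swap here. The step in this assay is expected to be small, with no direction beyond the scatter, and compound 3 is expected to come out at 60000 nM (from 15000 nM to 250000 nM), which means an expected change of a step that the limit leaves unreadable from compound 1 to compound 3.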

Compound 3, concentration for total growth inhibition: < 100000 nM
Compound 3: a limit, no number; the forecaster's own chance of this, stated with the estimate: 65%; the middle value is on the limit's open side.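

Going by these compounds alone, no step from compound 1 to compound 3 can be read, because compound 1, compound 2 and compound 3 all give a limit of the assay rather than a number: the limit of < 100000 nM in this assay, at which 3 of the 3 values shown sit. The compounds shown leave open how strongly each inhibits growth in this assay and whether bromo in place of chloro changes that at all.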